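The source may hold more compounds than are shown below. What is called first, only, known or untested is meant among the compounds shown, and "the series" means these compounds.

Three compounds have been measured in a functional assay on B16-F10 cells (Mus musculus) for antiproliferative activity, read by MTT assay, with a stated time of 48 h; on this read-out higher numbers stand for weaker inhibition and lower numbers for stronger inhibition:

- compound 1 `COc1ccc(/C=C/c2cc(OC)cc(OC)c2/C=C/C(=O)c2ccc(C)cc2)cc1` gives 5.3 ug/mL
- compound 2 `COc1ccc(/C=C/c2cc(OC)cc(OC)c2/C=C/C(=O)c2cccc(Br)c2)cc1` gives 5.1 ug/mL
- compound 3 `COc1ccc(/C=C/c2cc(OC)cc(OC)c2/C=C/C(=O)c2ccccc2C)cc1` gives 6.1 ug/mL

Compound 2 sits at the low end of these three numbers, yet the gaps to its neighbours are small: a 1.0-fold lower number from compound 1 to compound 2 (0.02 log units; within the scatter) and a 1.2-fold higher number from compound 2 to compound 3 (0.08 log units; within the scatter) are both within the scatter, as is a 1.2-fold higher number from compound 1 to compound 3 (0.06 log units; within the scatter). All three swaps of the ring on the carbonyl carbon thus leave the read-out essentially where it was.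

Compound 4 `CCN(CC)c1ccc(C(=O)/C=C/c2c(/C=C/c3ccc(OC)cc3)cc(OC)cc2OC)cc1` has not yet been measured. Compared with compound 2 the change is 4-(diethylamino)phenyl in place of 3-bromophenyl on a carbonyl carbon. Every measured step also exchanged the ring on the carbonyl carbon, and none of them moved the number beyond the scatter. Within the data shown here, a 4-(diethylamino)phenyl appears in no measured compound, so there is no direct precedent for it. The expectation in this assay is therefore a step of about a 1.1-fold higher number from compound 2 to compound 4 (0.03 log units; within the scatter), that is, none beyond the scatter, with the margin kept wide for the new group. Compound 4 is estimated at 5.5 ug/mL, within a range from 2.5 ug/mL to 12 ug/mL.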

Compound 4, half-maximal inhibitory concentration: 8.1 ug/mL
Compound 4: the middle estimate sits 1.5-fold (0.17 log units) below what was measured, and the stated range covers the measured number.
By their numbers in this assay, from the lowest: compounds 2, 1, 3 and 4 (each within the scatter of the next).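

In this assay, among these compounds, the 4-(diethylamino)phenyl group is the first on the carbonyl carbon to carry a nitrogen and a hydrogen-bond acceptor, yet all three new steps stay within the scatter: a 1.6-fold higher number from compound 2 to compound 4 (0.20 log units; within the scatter) and a 1.3-fold higher number from compound 3 to compound 4 (0.12 log units; within the scatter) and a 1.5-fold higher number from compound 1 to compound 4 (0.18 log units; within the scatter). The last of these is the closest comparison, since only diethylamino in place of methyl on an aromatic carbon separates the two compounds, so across these four compounds this position accepts a much bigger substituent without a clear shift in the read-out. Nothing available explains this result.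

As far as these compounds go, whether a carboxylic acid or a morpholine on this ring would move the number beyond the scatter remains open. So does whether a simple alkyl chain could replace the ring on the carbonyl carbon.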